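A few compounds are considered here, and "the series" means these few. Any claim that something is new, unique, unknown or untested is made for them only; others in the source may bear on it.

Going by the values given here, compound 2 `COc1cc(C(=O)N2CCc3ccccc32)cc(C#N)c1O` stands lowest of the two numbers so far in a toxicity assay on mitochondria from liver (Rattus norvegicus) for inhibition, tested at 100 uM, in the presence of a further agent that is not named here (a lower number here means less inhibition, a higher number more inhibition at the concentration tested (going by the name of the read-out)), where compound 2 gives -10%. Its nearest neighbour is compound 1 `N#Cc1cc(C(=O)N2CCc3ccccc32)ccc1O`, which in this assay gives 43%. Among the compounds with values here, the only measured step, a number 53 percentage points lower from compound 1 to compound 2 (beyond the scatter), is large and lies beyond the scatter. Compound 3 `N#Cc1cc(C(=O)N2CCc3ccccc32)cc(C#N)c1O` is reached from compound 2 by a single change: cyano in place of methoxy on an aromatic carbon. Within the data shown here, the step from compound 1 to compound 2 bears on this only in part: it shows that the methoxy group now leaving had accompanied a large fall in inhibition, but no measured pair shows a cyano group entering at this place, so the size of the coming step is uncertain. Compound 3 is therefore expected to rise by an estimated a number 30 percentage points higher from compound 2 to compound 3 (beyond the scatter), recovering part of that fall. Compound 3 is estimated at 20% in this assay, within a range from -10% to 50%.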

Compound 3, a percentage reported as inhibition, at one concentration (the size of the read-out at that concentration, not a potency): 47%
For compound 3 the middle estimate is 27 percentage points below the measured one, and the stated range covers the measured number.
By their numbers in this assay, from the lowest: compound 2; then compounds 1 and 3 (each within the scatter of the next).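

Cyano in place of methoxy on this aromatic carbon, ortho to a hydroxy group, gives a number 57 percentage points higher from compound 2 to compound 3 (beyond the scatter) in this assay, even though the two groups are counted alike in heavy atoms and hydrogen-bond acceptors. Cyano in place of hydrogen at the same carbon gives a number 4 percentage points higher from compound 1 to compound 3 (within the scatter), so hydrogen and cyano cannot be told apart here, and among the three groups only methoxy stands apart, with the low number of compound 2. Nothing available gives a reason for this difference.

Going by these compounds, whether an amine, a fluorine atom or ethoxy on this carbon would stand with methoxy or with hydrogen and cyano remains open. So does whether methoxy would have the same effect on compounds with a different core.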